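The source may hold more compounds than are shown below. What is called first, only, known or untested is meant among the compounds shown, and "the series" means these compounds.

In a functional assay on U-87MG ATCC cells for antiproliferative activity against U-87 MG (Homo sapiens), read by MTT assay, with a stated time of 48 h (a lower number here means a stronger inhibitor, a higher number a weaker inhibitor), compound 3 (`Cc1nc(-c2ccccc2)sc1C(=O)CSc1nc(-c2cccc(Cl)c2)c(C#N)c(=O)[nH]1`) gives 28200 nM. Compound 1 (`COc1ccc(-c2nc(C)c(C(=O)CSc3nc(-c4ccc(OC)cc4)c(C#N)c(=O)[nH]3)s2)cc1`) gives 25300 nM, a value within the scatter of that of compound 3. Compound 2 (`COc1ccc(-c2nc(C)c(C(=O)CSc3nc(-c4ccc(OC)c(OC)c4)c(C#N)c(=O)[nH]3)s2)cc1`) gives 12500 nM, a lower number than compound 3 shows, and the gap between them exceeds the scatter.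

Compound 4 (`COc1ccc(-c2nc(C)c(C(=O)CSc3nc(-c4cccc(Cl)c4)c(C#N)c(=O)[nH]3)s2)cc1`) differs from compound 3 in one place: methoxy in place of hydrogen on an aromatic carbon. This is methoxy in place of hydrogen on an aromatic carbon, read one bond further out as phenyl to 4-methoxyphenyl. For the measured compounds named here, only one measured step is of the same kind, a 2.0-fold lower number from compound 1 to compound 2 (0.31 log units; beyond the scatter). That step was modest, and it lies elsewhere in the molecule, so it is a loose guide rather than a direct precedent. Compound 1 and compound 2 already carry the 4-methoxyphenyl group, but each also differs from compound 4 at another place, so neither isolates the change. The data therefore point only weakly towards a lower number, and a shift no larger than the scatter would not be surprising. The expected change is a 1.4-fold lower number from compound 3 to compound 4 (0.15 log units; within the scatter). For compound 4 the estimated value is 20000 nM, with an expected range from 9000 nM to 42000 nM.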

Compound 4, half-maximal inhibitory concentration: 78900 nM
For compound 4 the middle estimate is 3.9-fold (0.60 log units) below the measured one; the whole stated range lies below it.
By their numbers in this assay, from the lowest: compound 2; then compounds 1 and 3 (each within the scatter of the next); then compound 4.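

In this assay, methoxy in place of hydrogen on an aromatic carbon, para to a large group, gives a 2.8-fold higher number from compound 3 to compound 4 (0.45 log units; beyond the scatter), so this change has no single direction across the compounds shown: the same change on two cores in this assay, a 2.0-fold lower number (0.31 log units; beyond the scatter) from compound 1 to compound 2 and a 2.8-fold higher number (0.45 log units; beyond the scatter) from compound 3 to compound 4, 5.7-fold (0.75 log units) apart, beyond the scatter of two such steps

With the 4-methoxyphenyl group held fixed, the other aromatic substituent also matters: 3-chlorophenyl in place of 4-methoxyphenyl gives a 3.1-fold higher number from compound 1 to compound 4 (0.49 log units; beyond the scatter), and 3-chlorophenyl in place of 3,4-dimethoxyphenyl gives a 6.3-fold higher number from compound 2 to compound 4 (0.80 log units; beyond the scatter). Compound 4, which carries 3-chlorophenyl together with 4-methoxyphenyl, thus has the highest number of the four in this assay, and its steps to all three others lie beyond the scatter.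

Two pairs cannot settle whether the opposite direction of the methoxy step goes with the 3-chlorophenyl group or with some other difference between the two cores. Also open, going by these compounds, is how an amine or a carboxylic acid in place of this methoxy on the six-membered aromatic ring would read in this assay.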